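The source may report more compounds than this note shows. Statements on the series, on what has been measured and on what is new or still open speak of the compounds shown alone.

Working notes on the cytotoxicity series. Compound 1 `O=C(CCNC(=O)c1cc(-c2cccc3ccccc23)cc(C(=O)NCCC(=O)NO)n1)NO` was tested in an ADME assay on Vero cells (Chlorocebus sabaeus) for cytotoxicity, read by resazurin assay, with a stated time of 69 h; a higher number here means that more compound is tolerated, a lower number that less compound is tolerated. Compound 1 gives only a limit there, > 100000 nM, not a number. Compound 2 `CSCCNC(=O)c1cccc(C(=O)NCCSC)n1` was run in this assay as well. Compound 2 likewise returns only a limit, > 100000 nM. Both readings sit at the limit of > 100000 nM in this assay, at which 2 of the 2 values shown sit, so compound 1 stands together with compound 2 at the edge of what this assay resolves, and no ordering of the two is possible. Compound 3 `O=C(CCNC(=O)c1cccc(C(=O)NCCC(=O)NO)n1)NO` has not yet been measured in this assay. It differs from compound 1 by hydrogen in place of naphthalen-1-yl on an aromatic carbon. Within the data shown here, no step between measured compounds is available for comparison; the expected step, a step that the limit leaves unreadable from compound 1 to compound 3, is taken as none beyond the scatter, and the reading will most likely again be a limit. Compound 3 is expected to give 150000 nM in this assay, between 50000 nM and 500000 nM.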

Compound 3, half-maximal cytotoxic concentration: > 100000 nM
Compound 3 ended at the assay's limit; the forecaster's own chance of this, stated with the estimate: 80%; the middle value is on the limit's open side.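

Compound 1 and compound 3 both give only limits in this assay, so no step can be read for hydrogen in place of naphthalen-1-yl: the limit of > 100000 nM in this assay, at which 3 of the 3 values shown sit.

The compounds shown leave open where compound 1, compound 2 and compound 3 would fall beyond that limit, and whether this exchange changes the reading at all.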